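Two anilides and a nitro swap on the amide nitrogen

The source may report more compounds than this note shows. Statements on the series, on what has been measured and on what is new or still open speak of the compounds shown alone.

Compound 1 `Cc1cnc(Nc2ccc(C#N)cc2)nc1OCC(=O)Nc1ccc(F)cc1`: > 331000 nM (a limit of the assay)
Compound 2 `Cc1cnc(Nc2ccc(C#N)cc2)nc1OCC(=O)Nc1ccccc1Cl`: 197000 nM

Within the data shown here, in an ADME assay on MT4 cells (Homo sapiens) for cytotoxicity, read by MTT assay, with a stated time of 5 days (on this read-out lower numbers stand for higher toxicity in this test and higher numbers for lower toxicity in this test), compound 2 gives 197000 nM, the only exact number so far. Compound 1 gives only a limit, > 331000 nM.

Compound 3 `Cc1cnc(Nc2ccc(C#N)cc2)nc1OCC(=O)Nc1ccc([N+](=O)[O-])cc1` carries 4-nitrophenyl in place of 2-chlorophenyl on an amide-type nitrogen.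

Among the measured compounds shown here, one measured step bears on this change, because it swaps groups on the same nitrogen: an at least 1.6-fold lower number from compound 1 to compound 2 (0.22 log units; that floor lies within the scatter). With so little evidence, no step beyond the scatter is expected in this assay, in either direction. The estimate means a 1.1-fold lower number from compound 2 to compound 3 (0.04 log units; within the scatter), which is expected to stay within the scatter. The expected value for compound 3 is 180000 nM, with an estimated range from 50000 nM to 330000 nM.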

Compound 3, half-maximal cytotoxic concentration: 66300 nM
Compound 3: the middle estimate sits 2.7-fold (0.43 log units) above what was measured; the range from low to high includes it.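

In this assay, the aryl group on the amide nitrogen can move the number beyond the scatter, which the earlier step could not show: the change gives a 3.0-fold lower number from compound 2 to compound 3 (0.47 log units; beyond the scatter). Nitro in place of fluoro on an aromatic carbon, with the rest of the molecule unchanged, gives an at least 4.9-fold lower number from compound 1 to compound 3 (0.69 log units; beyond the scatter), so this single swap on the ring is enough to bring the number down. Compound 1 stands at a limit of the assay and not at a number, so that second step is only a floor and its true size stays unknown: the limit of > 331000 nM in this assay, at which 1 of the 3 values shown sits.

With one nitro compound shown, it remains open whether the lower number is special to nitro or would also appear with other groups. An amine or a carboxylic acid at the same ring carbon would help to settle this.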